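Acylguanidine diene series: shortening one terpenoid chain

A few compounds are considered here, and "the series" means these few. Any claim that something is new, unique, unknown or untested is made for them only; others in the source may bear on it.

Measured so far:
compound 1 `CC(C)=CCC/C(C)=C/C(=O)NC(=N)NC(=O)C=C(C)C` — 53400 nM
compound 2 `CC(C)=CCC/C(C)=C/CC/C(C)=C/C(=O)NC(=N)NC(=O)/C=C(\C)CC/C=C(\C)CCC=C(C)C` — 42700 nM

In a functional assay on SK-MEL-28 cells (Homo sapiens) for inhibition, read by MTT assay, with a stated time of 72 h (a lower number here means a stronger inhibitor of growth, a higher number a weaker inhibitor of growth), compound 2 gives 42700 nM. In this assay compound 1 gives 53400 nM, and the two values lie within the scatter of each other, so no order between them can be read. Compound 3 `CC(C)=CCC/C(C)=C/CC/C(C)=C/C(=O)NC(=N)NC(=O)/C=C(\C)CCC=C(C)C` differs from compound 2 by hydrogen in place of 3-methylbut-2-en-1-yl on a saturated chain carbon bound to a double-bonded chain carbon, cutting one chain back to the length seen on both sides of compound 1. With compound 1 and compound 2 so close, the step is expected to be small and within the scatter, a 1.1-fold higher number from compound 2 to compound 3 (0.04 log units; within the scatter). Compound 3 is estimated at 47000 nM, within 24000 nM to 92000 nM.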

Compound 3, concentration for 50% growth inhibition: 57300 nM
Compound 3: middle estimate off by 1.2-fold (0.09 log units), on the low side, and the stated range covers the measured number.
By their numbers in this assay, from the lowest: compounds 2, 1 and 3 (each within the scatter of the next).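

Removing 3-methylbut-2-en-1-yl from the saturated chain carbon bound to a double-bonded chain carbon gives in this assay a 1.3-fold higher number from compound 2 to compound 3 (0.13 log units; within the scatter) and so does not separate these two chain lengths. Putting 3,7-dimethylocta-2,6-dien-1-yl in place of hydrogen at that kind of carbon on the other side gives a 1.1-fold higher number from compound 1 to compound 3 (0.03 log units; within the scatter) and likewise separates nothing. No measurement shown bears on a cause for this.

Still open, as far as these compounds go, is whether an amine, a carboxylic acid or a longer chain in place of 3-methylbut-2-en-1-yl would give a step beyond the scatter.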